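The compounds below may be only part of what the source reports. "The series", "measured", "known", "first", "only" and "open" are said of these compounds alone.

Compound 2 `O=C(OC/C(=C\C1CCCCC1)C(=O)c1ccccc1)c1ccccc1` gives 19000 nM in a functional assay on WiDr cells (Homo sapiens) for inhibition, read by sulforhodamine B assay, with a stated time of 48 h; a lower number here means a stronger inhibitor of growth, a higher number a weaker inhibitor of growth; compound 1 `CC(=O)OC/C(=C\C1CCCCC1)C(=O)c1ccccc1` gives 21000 nM, and the step of a 1.1-fold lower number from compound 1 to compound 2 (0.04 log units; within the scatter) leaves the two indistinguishable. Compound 3 `O=C(OC/C(=C\c1ccccc1[N+](=O)[O-])C(=O)c1ccccc1)c1ccccc1` differs from compound 2 by 2-nitrophenyl in place of cyclohexyl on a double-bonded chain carbon bound to a double-bonded chain carbon. Within the data shown here, the only measured step, a 1.1-fold lower number from compound 1 to compound 2 (0.04 log units; within the scatter), concerns the carbonyl carbon of the ester and not the double-bonded chain carbon, so nothing measured bears directly on this change; no step yet exchanges the cyclohexyl. The expected step is a 1.3-fold lower number from compound 2 to compound 3 (0.10 log units; within the scatter), small enough to stay within the scatter. Compound 3 is estimated at 15000 nM, with a range from 4000 nM to 60000 nM.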

Compound 3, concentration for 50% growth inhibition: 18000 nM
The estimate for compound 3 lay 1.2-fold (0.08 log units) below the measured number; the range from low to high includes it.
By their numbers in this assay, from the lowest: compounds 3, 2 and 1 (each within the scatter of the next).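

At the double-bonded chain carbon bound to a double-bonded chain carbon, the exchange of cyclohexyl for 2-nitrophenyl gives a 1.1-fold lower number from compound 2 to compound 3 (0.02 log units; within the scatter) in this assay. Among these compounds, this is the first measured change at this position, and an aromatic ring bearing a nitro group reads the same as a non-aromatic ring of carbon only, for this pair alone. No measured evidence accounts for this result.

On these data alone, whether unsubstituted phenyl, or an amine or carboxylic acid on that ring, would shift the number remains open. So does the effect of a longer chain in place of the ring.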